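Removing an isobutyl group from compound 1

A few compounds are considered here, and "the series" means these few. Any claim that something is new, unique, unknown or untested is made for them only; others in the source may bear on it.

Among the compounds with values here, only two compounds have numbers so far in a functional assay on HeLa cells (Homo sapiens) for cytotoxicity, read by MTT assay, with a stated time of 72 h; a lower number here means a stronger inhibitor, a higher number a weaker inhibitor. Compound 1 (`CC1=CCC[C@H]2[C@](C)(CC3=CC(=O)C=C(N[C@@H](CC(C)C)C(=O)O)C3=O)[C@@H](C)CC[C@]12C`) gives 7720 nM, the lower of the two, while compound 2 (`CC(C)(C)C1=CC(=O)C=CC1=O`) gives 44100 nM. Compound 1 is therefore the stronger inhibitor of this pair, by a gap beyond the usual scatter.

Compound 3 (`CC1=CCC[C@H]2[C@](C)(CC3=CC(=O)C=C(NCC(=O)O)C3=O)[C@@H](C)CC[C@]12C`) has not yet been measured. It keeps the core of compound 1 and differs in one place: hydrogen in place of isobutyl on a saturated chain carbon bound to an amine nitrogen and a carbonyl carbon. In words, hydrogen stands in place of isobutyl on a saturated chain carbon bound to an amine nitrogen and a carbonyl carbon, so (1-carboxy-3-methylbutyl)amino becomes (carboxymethyl)amino.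

Within the data shown here, no measured pair differs in just one place, so the data offer no earlier step as a guide. A modest move in this assay is expected, most likely toward a somewhat higher number and thus a weaker inhibitor, though it may not clear the scatter. The estimated change is a 1.4-fold higher number from compound 1 to compound 3 (0.15 log units; within the scatter). For compound 3 the expected value is 11000 nM, with an estimated range from 4500 nM to 28000 nM.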

Compound 3, half-maximal inhibitory concentration: 19900 nM
For compound 3 the middle estimate is 1.8-fold (0.26 log units) below the measured one, and the stated range covers the measured number.
By their numbers in this assay, from the lowest: compound 1; then compound 3; then compound 2.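

Within the data shown here, this is the first step in this assay that changes only one place, so the isobutyl group on the saturated chain carbon bound to an amine nitrogen and a carbonyl carbon can now be judged alone. Putting hydrogen there gives a 2.6-fold higher number from compound 1 to compound 3 (0.41 log units; beyond the scatter), which means that the isobutyl group contributes to the stronger inhibition of compound 1, but that the core and the rest of the (1-carboxy-3-methylbutyl)amino group do not depend on it for all of their activity. No measured information explains why the number moves this way.

On these data alone, with a single replacement at this position, it remains open whether a smaller methyl group, a longer chain or a benzyl group would match compound 1, improve on it or fall closer to compound 3. As far as these compounds go, it also remains open how much the carboxylic acid, present in both compounds, contributes, and a methyl ester or an amide in its place would test this.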